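Replacing the Amino Link: Expected Effect on Growth Inhibition

This account rests on a few compounds, and the source may have more. Where it says the series, first, only, none or still open, it means among the compounds named here.

Compound 2 `COc1cc(Cl)cc(-c2nn(-c3cccc(NC(=O)Nc4cccc(C(F)(F)F)c4)c3)cc2-c2ccncc2)c1` was tested in a functional assay on SN12C cells (Homo sapiens) for inhibition, read by sulforhodamine B assay, with a stated time of 48 h, tested at 0.01 uM (on this read-out higher numbers stand for a weaker effect at the one concentration tested and lower numbers for a stronger effect), where compound 2 gives 101%. Among the two measured numbers this is the highest, but its only neighbour, compound 1 `COc1cc(Cl)cc(-c2nn(-c3cccc(NC(=O)Nc4ccc(Cl)c(C(F)(F)F)c4)c3)cc2-c2ccncc2)c1`, lies within the scatter of it: in this assay compound 1 gives 98%, and the step of a number 3 percentage points higher from compound 1 to compound 2 (within the scatter) changes nothing beyond the scatter. Compound 3 `COc1cc(Cl)cc(-c2nn(-c3cccc(NC(=O)c4cccc(C(F)(F)F)c4)c3)cc2-c2ccncc2)c1` is not yet measured. It differs from compound 2 by 3-(trifluoromethyl)phenyl in place of (3-(trifluoromethyl)phenyl)amino on a carbonyl carbon, so one hydrogen-bond donor is lost at the carbonyl carbon. Among the compounds with values here, no measured step touches this part of the molecule; the single known step, a number 3 percentage points higher from compound 1 to compound 2 (within the scatter), concerns a different place and stayed within the scatter. There is thus no basis for expecting a change beyond the scatter, and compound 3 is estimated at 99%, between 86% and 110%. The expected step of a number 2 percentage points lower from compound 2 to compound 3 (within the scatter) is within the scatter.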

Compound 3, a percentage reported as activity, at one concentration (the size of the read-out at that concentration, not a potency): 99%
Compound 3: the middle estimate sits on the measured number at the digits printed, within the range that was stated.
By their numbers in this assay, from the lowest: compounds 1, 3 and 2 (each within the scatter of the next).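

Swapping (3-(trifluoromethyl)phenyl)amino for 3-(trifluoromethyl)phenyl on the carbonyl carbon removes one hydrogen-bond donor, and in this assay this gives a number 2 percentage points lower from compound 2 to compound 3 (within the scatter) as the first reading at this position. The earlier step concerned only a chloro on the aromatic ring, whereas this one changes the link itself. The comparison with the chloro-bearing compound reads the same (a number 1 percentage points higher from compound 1 to compound 3 (within the scatter)), so at this one concentration the amino link can be replaced without separating the three compounds, and no measured property is available to explain this.

From the compounds shown here alone, whether an aliphatic amine or a carboxylic acid on the carbonyl carbon would shift the number remains open. Also open, going by these compounds, is whether the amino link matters at other concentrations, since one concentration says nothing about potency.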